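Extending the linker beyond compound 2 toward compound 3

The source may report more compounds than this note shows. Statements on the series, on what has been measured and on what is new or still open speak of the compounds shown alone.

Among the measured compounds shown here, in an assay on cells for inhibition of protein deacetylase HDAC6 (Homo sapiens), read by fluorescence, with stated times of 15 min and 60 min (a lower number here means a stronger inhibitor, a higher number a weaker inhibitor), compound 2 `O=C(CCCCNC(=O)c1cc(-c2ccc(F)cc2)[nH]n1)NO` gives 275 nM, the highest of the two numbers measured so far; compound 1 `O=C(CCCCCNC(=O)c1cc(-c2ccc(F)cc2)[nH]n1)NO` gives 29 nM. For the measured compounds named here, the only measured step that bears on the next change is a 9.5-fold higher number from compound 1 to compound 2 (0.98 log units; beyond the scatter). Compound 3 `O=C(CCCCCCNC(=O)c1cc(-c2ccc(F)cc2)[nH]n1)NO` carries 2-(hydroxycarbamoyl)ethyl in place of hydroxycarbamoyl on a saturated chain carbon, four bonds along the chain from an amide-type nitrogen, a change running opposite to that step and reaching past the chain length of compound 1. Going by the values given here, a drop beyond the scatter in this assay is therefore expected, of about a 6.1-fold lower number from compound 2 to compound 3 (0.79 log units; beyond the scatter), though the longer chain has no measured counterpart. Compound 3 is estimated at 45 nM, between 12 nM and 160 nM.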

Compound 3, half-maximal inhibitory concentration: 22 nM
The estimate for compound 3 lay 2.0-fold (0.31 log units) above the measured number; low and high end bracket the measured number.
By their numbers in this assay, from the lowest: compounds 3 and 1 (each within the scatter of the next); then compound 2.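

In this assay the position tolerates more chain than the earlier pair could show: 2-(hydroxycarbamoyl)ethyl in place of hydroxycarbamoyl gives a large step (a 13-fold lower number from compound 2 to compound 3 (1.10 log units; beyond the scatter)). Going past the chain of compound 1 adds nothing that can be read (a 1.3-fold lower number from compound 1 to compound 3 (0.12 log units; within the scatter)), so among these three compounds only compound 2 stands apart. No accompanying data bear on why the chain length matters. On these data alone, whether a still longer chain holds this level remains open. So does the effect of a carboxylic acid in place of hydroxycarbamoyl at the chain end.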